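Amide substituent swap at the carboxamide of the shared core

The compounds below may be only part of what the source reports. "The series", "measured", "known", "first", "only" and "open" are said of these compounds alone.

Compound 1 `CCn1c(C(=O)NCCNC(=O)OC(C)(C)C)ccc1C(CC)(CC)c1ccc(OCS(=O)(=O)c2ccccc2)c(C)c1` is tested in a functional assay on PC-3 cells (Homo sapiens) for antiproliferative activity, read by MTT assay, with a stated time of 24 h; on this read-out higher numbers stand for weaker inhibition and lower numbers for stronger inhibition. In this assay compound 1 gives > 50000 nM, which is a limit of the assay rather than a number. Compound 1 therefore stands at the limit of > 50000 nM in this assay, at which 1 of the 2 values shown sits. Going by the values given here, compound 2 `CCn1c(C(=O)N[C@H](CO)C(C)C)ccc1C(CC)(CC)c1ccc(OCS(=O)(=O)c2ccccc2)c(C)c1` gives 7300 nM in this assay, and the step of an at least 6.8-fold lower number from compound 1 to compound 2 (0.83 log units; beyond the scatter) is the only measured step available.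

Compound 3 `CCn1c(C(=O)N[C@@H](CO)C(C)C)ccc1C(CC)(CC)c1ccc(OCS(=O)(=O)c2ccccc2)c(C)c1` differs from compound 1 by 1-(hydroxymethyl)-2-methylpropyl in place of 2-((tert-butoxycarbonyl)amino)ethyl on an amide-type nitrogen; the entering group is the same as in compound 2 but with the opposite configuration at its defined stereocentre. Among the compounds with values here, the one measured step, from compound 1 to compound 2, bears directly on this change, so a step of comparable size and direction is expected. The expected step of an at least 5.0-fold lower number from compound 1 to compound 3 (0.69 log units; beyond the scatter) is accordingly a decrease from the limit. Compound 3 is estimated at 10000 nM, with a range from 3000 nM to 40000 nM.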

Compound 3, half-maximal inhibitory concentration: 10600 nM
Beside the measured number, compound 3's estimate is 1.1-fold (0.03 log units) below it; the measured number falls inside the stated range.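

In this assay the configuration at the defined stereocentre of the 1-(hydroxymethyl)-2-methylpropyl group is not separated by this read-out, with a 1.5-fold higher number from compound 2 to compound 3 (0.16 log units; within the scatter), and this pair isolates that single feature: the fact that compounds 2 and 3 differ only in the configuration as drawn. Both configurations of this group on the amide-type nitrogen read stronger than the 2-((tert-butoxycarbonyl)amino)ethyl group, with an at least 4.7-fold lower number from compound 1 to compound 3 (0.67 log units; beyond the scatter). The value of compound 1 is a limit of the assay and not a number: the limit of > 50000 nM in this assay, at which 1 of the 3 values shown sits.

Which part of the 1-(hydroxymethyl)-2-methylpropyl group goes with the step from compound 1 stays open. Also open, going by these compounds, is how a primary amine, a carboxylic acid or a longer chain carrying a terminal hydroxyl on the same amide-type nitrogen would read in this assay.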